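A few compounds are considered here, and "the series" means these few. Any claim that something is new, unique, unknown or untested is made for them only; others in the source may bear on it.

Compounds measured in an ADME assay on HEK293 cells (Homo sapiens) for cytotoxicity; on this read-out lower numbers stand for stronger inhibition and higher numbers for weaker inhibition:
compound 1 `CCCCCCCCCCCCCCNC(=O)[C@H](CO)/N=C/c1ccccc1Cl` gives 94900 nM
compound 2 `CCCCCCCCCCCCCCNC(=O)[C@H](CO)/N=C/c1ccc(C)cc1` gives 47300 nM
compound 3 `CCCCCCCCCCCCCCNC(=O)[C@H](CO)/N=C/c1ccccc1C` gives 81100 nM

Compound 1 shows the highest number of the three, yet its neighbours sit close: a 1.2-fold lower number from compound 1 to compound 3 (0.07 log units; within the scatter) and a 2.0-fold lower number from compound 1 to compound 2 (0.30 log units; within the scatter), both within the scatter. The third pair behaves the same way: a 1.7-fold higher number from compound 2 to compound 3 (0.23 log units; within the scatter). Compound 4 `CCCCCCCCCCCCCCNC(=O)[C@H](CO)/N=C/c1cccc(O)c1` is not yet measured; it differs from compound 1 in one place, (3-hydroxyphenyl in place of 2-chlorophenyl on a carbon with a double bond to nitrogen). For the measured compounds named here, no measured step exchanges chloro for hydroxy or moves a group to that position, so the comparison rests on the general picture: every change tried so far on this ring left the read-out in this assay within the scatter. Compound 4 is therefore expected to give 80000 nM (range 35000 nM to 200000 nM), a step of a 1.2-fold lower number from compound 1 to compound 4 (0.07 log units; within the scatter) expected to stay within the scatter.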

Compound 4, half-maximal inhibitory concentration: 77500 nM
Compound 4: middle estimate off by 1.0-fold (0.01 log units), on the high side, and the stated range covers the measured number.
By their numbers in this assay, from the lowest: compounds 2, 4, 3 and 1 (each within the scatter of the next).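

In this assay, the 3-hydroxyphenyl group brings a hydrogen-bond donor and a hydrogen-bond acceptor that the 2-chlorophenyl group lacks, yet the steps stay within the scatter: a 1.2-fold lower number from compound 1 to compound 4 (0.09 log units; within the scatter), a 1.0-fold lower number from compound 3 to compound 4 (0.02 log units; within the scatter) and a 1.6-fold higher number from compound 2 to compound 4 (0.21 log units; within the scatter). At this position, on a carbon with a double bond to nitrogen, this exchange therefore gives no difference that can be read, and no evidence at hand bears on the result. From the compounds shown here alone, it remains open whether an amine or a carboxylic acid in place of the hydroxy group would give a step beyond the scatter.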